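This account rests on a few compounds, and the source may have more. Where it says the series, first, only, none or still open, it means among the compounds named here.

Measured in a functional assay on the whole organism (strain Wistar) for inhibition, with Rattus norvegicus as the target, read by paw edema, with stated times of 30 min and 2 h, at a dose of 20 mg/kg (on this read-out higher numbers stand for more inhibition at the one dose given (going by the name of the read-out) and lower numbers for less inhibition), the compounds were:

Compound 1 `CCOC(=O)C1=C(C)NC(C)=C(C(=O)OCC)C1c1ccc(OCC(=O)NNC(=O)c2cccs2)cc1`: 62.2%
Compound 2 `CCOC(=O)C1=C(C)NC(C)=C(C(=O)OCC)C1c1ccc(OCC(=O)NNC(=O)c2ccsc2Cl)cc1`: 52.8%
Compound 3 `CCOC(=O)C1=C(C)NC(C)=C(C(=O)OCC)C1c1ccc(OCC(=O)n2nc(C)cc2C)cc1`: 46.1%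

Compound 3 gives the lowest of the three numbers in this assay; its nearest neighbour is compound 2, whose value lies within the scatter of it, while compound 1 stands beyond the scatter above it, as the step of a number 16.1 percentage points lower from compound 1 to compound 3 (beyond the scatter) shows. Compound 4 `CCOC(=O)C1=C(C)NC(C)=C(C(=O)OCC)C1c1ccc(OCC(=O)NN2C(=O)c3ccccc3C2=O)cc1` differs from compound 3 in one place: a group of 12 heavy atoms (8 carbon, 2 nitrogen, 2 oxygen; one five-membered non-aromatic ring with 1 hetero atom, one six-membered aromatic ring of carbon only) in place of a group of 7 heavy atoms (5 carbon, 2 nitrogen; one five-membered aromatic ring with 2 hetero atoms), on a carbonyl carbon. Among the compounds with values here, the steps that bear on this change are those at the same carbonyl carbon, a number 16.1 percentage points lower from compound 1 to compound 3 (beyond the scatter) and a number 6.7 percentage points lower from compound 2 to compound 3 (within the scatter), in which the 3,5-dimethyl-1H-pyrazol-1-yl group took the place of a group carrying an amino-linked carbonyl with a hydrogen-bond donor, and the number fell. The entering group in compound 4 again brings one hydrogen-bond donor, so a rise in this assay of about the same size is expected, estimated as a number 9.9 percentage points higher from compound 3 to compound 4 (within the scatter). Compound 4 is therefore expected to give about 56% in this assay, estimated between 42% and 68%.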

Compound 4, a percentage reported as inhibition, in the whole organism at one dose (the size of the read-out at that dose, not a potency): 57.2%
The estimate for compound 4 lay 1.2 percentage points below the measured number, and the stated range covers the measured number.
By their numbers in this assay, from the lowest: compounds 3, 2, 4 and 1 (each within the scatter of the next, the first and the last beyond it).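

Within the data shown here, putting the group with the five-membered non-aromatic ring and the six-membered aromatic ring of carbon only on this carbonyl carbon, in place of 3,5-dimethyl-1H-pyrazol-1-yl, gives a number 11.1 percentage points higher from compound 3 to compound 4 (beyond the scatter) in this assay and so shows a second group, besides the one in compound 1, that stands clear of the pyrazole. Read on the amide-type nitrogen, the same change gives a number 4.4 percentage points higher from compound 2 to compound 4 (within the scatter) and also a number 5 percentage points lower from compound 1 to compound 4 (within the scatter) so that, among these compounds, a thiophene ring is not required for a number of this size. No measurement is at hand that explains these steps.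

Going by these compounds, whether a plain amine or a carboxylic acid on this carbonyl carbon would hold such a number remains open. So does the question of which ring of the entering group carries the step.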